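A few compounds are considered here, and "the series" means these few. Any claim that something is new, unique, unknown or untested is made for them only; others in the source may bear on it.

Working notes on the series in an ADME assay on L6 cells (Rattus norvegicus) for cytotoxicity, read by fluorescence and resazurin assay, with a stated time of 72 h; a lower number here means that less compound is needed, a higher number that more compound is needed for the effect.

Compound 1 `Cc1ccncc1-c1ccc2[nH]c(=O)nc(-c3ccccc3)c2c1` gives in this assay only a limit, > 50000 nM. Its value therefore stands at the limit of > 50000 nM in this assay, at which 2 of the 3 values shown sit. Compound 2 `O=c1nc(-c2ccccc2)c2cc(-c3ccc(N4CCCC4)nc3)ccc2[nH]1` likewise gives in this assay only a limit, > 50000 nM. Compound 3 `O=c1nc(-c2ccccc2)c2cc(-c3cnc4ccccc4c3)ccc2[nH]1` gives in this assay a limit as well, > 16000 nM, which is the limit of > 16000 nM in this assay, at which 1 of the 3 values shown sits. For the measured compounds named here, no step between two measured compounds can be sized here, as all three values are limits; together they show that none of the measured compounds reached a measurable effect in this assay.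

Compound 4 `N#Cc1ccc(-c2ccc3[nH]c(=O)nc(-c4ccccc4)c3c2)cc1` is not yet measured. It differs from compound 1 by 4-cyanophenyl in place of 4-methylpyridin-3-yl on an aromatic carbon. Nothing among the three measured compounds points to a change beyond the scatter for this assay, so the step from compound 1 to compound 4 is expected to be a number no higher from compound 1 to compound 4 (the limit leaves the size open). For compound 4 the estimate in this assay is 50000 nM, with a range from 20000 nM to 120000 nM, and most likely the assay will again report only a limit.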

Compound 4, half-maximal effective concentration: > 50000 nM
Compound 4: no number, only a limit; the forecaster's own chance of this, stated with the estimate: 85%; the middle value sits exactly at the limit.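

In this assay compound 4 gives only a limit, > 50000 nM. For the compounds shown here, compound 1 also gives only a limit, so no step between compound 1 and compound 4 can be read. The compounds shown leave open at what concentration any of them would reach half-maximal effect in this assay.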